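Working notes: replacing methylamino in a brominated series

The source may hold more compounds than are shown below. What is called first, only, known or untested is meant among the compounds shown, and "the series" means these compounds.

Measured in a toxicity assay on C8166 cells (Homo sapiens) for cytotoxicity, read by MTT assay, with a stated time of 72 h (on this read-out higher numbers stand for lower toxicity in this test and lower numbers for higher toxicity in this test), so far
compound 1 `CS(=O)(=O)Oc1c(C(=O)NCc2ccc(F)cc2)nc(Br)c2cccnc12` - 48000 nM
compound 2 `CNc1c(C(=O)NCc2ccc(F)cc2)nc(Br)c2cccnc12` - "not determined" (no result reported)

Compound 2 has no single number in this assay and gives no starting value for the next comparison. On these data alone, its standing against compound 1 remains open. Among the compounds with values here, the only number belongs to compound 1 (48000 nM), which shares the core with the other two compounds.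

Compound 3 `Cc1ccc(S(=O)(=O)Oc2c(C(=O)NCc3ccc(F)cc3)nc(Br)c3cccnc23)cc1` has not yet been measured. The structural change runs (((4-methylphenyl)sulfonyl)oxy in place of methylamino on an aromatic carbon), with ((4-methylphenyl)sulfonyl)oxy in place of methylamino on an aromatic carbon, para to a bromo group. Within the data shown here, no measured step shows what this change does, and the data offer no direct guide to its size. Against compound 1 (48000 nM), the expectation in this assay is for no step beyond the usual scatter, and neither direction is favoured. Compound 3 is expected at 35000 nM, with an estimated range of 12000 nM to 100000 nM in this test.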

Compound 3, half-maximal cytotoxic concentration: 31000 nM
Compound 3: middle estimate off by 1.1-fold (0.05 log units), on the high side, within the range that was stated.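

With the sulfonyloxy link kept on the aromatic carbon para to a bromo group, 4-methylphenyl in place of methyl on the sulfonyl sulfur gives, in this assay, a 1.5-fold lower number from compound 1 to compound 3 (0.19 log units; within the scatter) and so does not separate the two sulfonate esters in this test. At this position, then, a substituent of 11 heavy atoms carrying a six-membered aromatic ring of carbon only reads the same within the scatter as the methyl counterpart in compound 1, which a single number could not show; the replacement of methylamino itself cannot be read, as compound 2 has no single number to start from. No supporting measurement is at hand to account for this result.

Open, on these data alone, is whether the flat reading in this assay would hold for other groups on the sulfonyl sulfur, such as a dimethylamino group, a butyl chain or a 4-carboxyphenyl group. Also open, as far as these compounds go, is how the shared core reads in this test with a hydroxyl group or a primary amine at this position in place of the sulfonyloxy link.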